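Cytotoxicity notes on a shared quinolone-type series

The compounds below may be only part of what the source reports. "The series", "measured", "known", "first", "only" and "open" are said of these compounds alone.

Two measured compounds share a core carrying two methoxy groups. Compound 1 is `COc1cc2c(=O)c(C(=O)c3ccc(C)cc3)cn(Cc3ccc(S(N)(=O)=O)cc3)c2cc1OC` and compound 2 is `COc1cc2c(=O)c(S(=O)(=O)CCc3ccc(Cl)cc3)cn(Cc3ccccc3)c2cc1OC`. In an ADME assay on Huh-7 cells (Homo sapiens) for cytotoxicity (on this read-out higher numbers stand for weaker inhibition of growth and lower numbers for stronger inhibition of growth), compound 1 is reported only as a limit of the assay, > 25000 nM, and no number sits behind it. Compound 2 in this assay is recorded as "not active" (no number reported), again with no number given. Compound 1 therefore stands at the limit of > 25000 nM in this assay, at which 1 of the 2 values shown sits, and neither value allows a step between the two to be sized.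

The unmeasured compound 3 is `COc1cc2c(=O)c(C(=O)c3ccc(C)cc3)cn(Cc3ccc(C(C)(C)C)cc3)c2cc1OC`. It differs from compound 1 by tert-butyl in place of sulfamoyl on an aromatic carbon. Within the data shown here, no measured step covers such a change, so the expected step from compound 1 to compound 3 in this assay, a step that the limit leaves unreadable from compound 1 to compound 3, is put at nothing beyond the scatter, with the reading of compound 3 most likely again ending at a limit. Compound 3 is expected to give 30000 nM in this assay, with a range from 8000 nM to 100000 nM.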

Compound 3, concentration for 50% growth inhibition: > 25000 nM
Compound 3 ended at the assay's limit; the forecaster's own chance of this, stated with the estimate: 65%; the middle value is on the limit's open side.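

Among these compounds, compound 1 and compound 3 both end at a limit of the measurement, so no step between them can be read for tert-butyl in place of sulfamoyl. The compounds shown leave open whether any change on the shared core gives a growth-inhibition value as an actual number.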